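A Chlorophenyl Added to the Piperazine Arm

The source may report more compounds than this note shows. Statements on the series, on what has been measured and on what is new or still open speak of the compounds shown alone.

Of the compounds shown here, three sharing one core have been measured in a functional assay on MCF7 cells (Homo sapiens) for cytotoxicity, read by MTT assay, with a stated time of 24 h, tested at 80 ug/mL; on this read-out lower numbers stand for a weaker effect and higher numbers for a stronger effect at the one concentration tested. Compound 1 `Cn1c(-c2ccc(NC(=O)CSc3nc4cc(Cl)ccc4o3)cc2)nc(-c2ccccc2)c1-c1ccccc1` gives 69.1%, compound 2 `Cn1nnnc1SCC(=O)Nc1ccc(-c2nc(-c3ccccc3)c(-c3ccccc3)n2C)cc1` gives 77.7%, and compound 3 `CN1CCN(CC(=O)Nc2ccc(-c3nc(-c4ccccc4)c(-c4ccccc4)n3C)cc2)CC1` gives 50.3%. Compound 3 stands lowest of the three: the step of a number 18.8 percentage points lower from compound 1 to compound 3 (beyond the scatter) and the step of a number 27.4 percentage points lower from compound 2 to compound 3 (beyond the scatter) both lie beyond the scatter, while the step of a number 8.6 percentage points higher from compound 1 to compound 2 (within the scatter) does not.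

Compound 4 `Cn1c(-c2ccc(NC(=O)CN3CCN(Cc4ccc(Cl)cc4)CC3)cc2)nc(-c2ccccc2)c1-c1ccccc1` is not yet measured. It differs from compound 3 in one place: 4-chlorophenyl in place of hydrogen on a saturated chain carbon bound to an amine nitrogen in a ring. Among the compounds with values here, no measured step alters this position, so none bears directly on the change. The two steps into compound 3 show that removing the ring-bearing sulfanyl groups of compound 1 and compound 2 lowered the number modestly; compound 4 brings an aromatic ring back at a different place, which is only loose guidance. A modest rise is therefore expected, the step of a number 9.7 percentage points higher from compound 3 to compound 4 (within the scatter) estimated as likely in this assay. Compound 4 is expected to give about 60%, within a range from 42% to 78%.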

Compound 4, a percentage reported as activity, at one concentration (the size of the read-out at that concentration, not a potency): 52.9%
For compound 4 the middle estimate is 7.1 percentage points above the measured one; measured number inside the range.
By their numbers in this assay, from the lowest: compounds 3 and 4 (each within the scatter of the next); then compounds 1 and 2 (each within the scatter of the next).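

In this assay, putting 4-chlorophenyl on a saturated chain carbon bound to an amine nitrogen in a ring gives a number 2.6 percentage points higher from compound 3 to compound 4 (within the scatter). Within the data shown here, this is the first reading at this position, and it shows that a group of this size, with its six-membered aromatic ring of carbon only, can sit there without a difference that this read-out can separate from the scatter. No measurement shown here explains this result.

As far as these compounds go, whether a plain phenyl, a 4-methoxyphenyl or a carboxylic acid on that same carbon, or a longer chain leading to the 4-chlorophenyl, would give a number beyond the scatter remains open. From the compounds shown here alone, each number also comes from a single concentration, so how the potencies of compound 3 and compound 4 compare remains open too.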